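From compound 3 to compound 4, all at the limit

The source may report more compounds than this note shows. Statements on the series, on what has been measured and on what is new or still open speak of the compounds shown alone.

In a functional assay on 4T1 cells (Mus musculus) for cytotoxicity, read by MTT assay, with a stated time of 48 h (on this read-out higher numbers stand for weaker inhibition and lower numbers for stronger inhibition), compound 3 `COc1ccc(/C=C/C(=O)/C=C/c2cc3ccccc3nc2Oc2ccc(Br)cc2)c(OC)c1` gives > 10000 nM and this is a limit, not a number. Compound 1 `COc1ccc(/C=C/C(=O)/C=C/c2cc3ccccc3nc2Cl)c(OC)c1` also gives only a limit, with > 10000 nM on the same read-out. Compound 2 `COc1ccc(/C=C/C(=O)/C=C/c2cc3ccccc3nc2Oc2ccc(Br)cc2)cc1` also gives only a limit, with > 10000 nM on the same read-out. Going by the values given here, the picture so far is therefore the limit of > 10000 nM in this assay, at which 3 of the 3 values shown sit, and no measured compound can be ranked against another.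

Compound 4 `COc1ccc(OC)c(/C=C/C(=O)/C=C/c2cc3ccccc3nc2Oc2ccc(Br)cc2)c1` differs from compound 3 as follows: 2,5-dimethoxyphenyl in place of 2,4-dimethoxyphenyl on a double-bonded chain carbon bound to a double-bonded chain carbon with the same atoms joined differently.

Among the compounds with values here, two measured steps touch compound 3, and neither has a readable size. The step for the added methoxy is a step that the two limits leave unreadable from compound 2 to compound 3 while the step for 4-bromophenoxy in place of chloro is a step that the two limits leave unreadable from compound 1 to compound 3 as well. Neither offers a size to carry over to the new change, so no step beyond the scatter is expected in this assay and no direction is favoured. The expected step is a step that the limit leaves unreadable from compound 3 to compound 4 on this estimate. Compound 4 is estimated at 12000 nM with an expected range from 4000 nM to 30000 nM and another limit is the likeliest report.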

Compound 4, half-maximal inhibitory concentration: > 10000 nM
Compound 4 ended at the assay's limit; the forecaster's own chance of this, stated with the estimate: 75%; the middle value lies beyond the limit too.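

In this assay compound 4 gives > 10000 nM, which is a limit and not a number. The steps to compound 4 from compound 3 and from compound 2 therefore cannot be read, and the series stays at one reading: the limit of > 10000 nM in this assay, at which 4 of the 4 values shown sit.

Still open, going by these compounds, is whether 2,5-dimethoxyphenyl and 2,4-dimethoxyphenyl differ at all in this assay.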